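Sulfonamide series: cytotoxicity toward mouse macrophage-like cells

This account rests on a few compounds, and the source may have more. Where it says the series, first, only, none or still open, it means among the compounds named here.

Compound 1 `Cc1cc2cc(NS(=O)(=O)c3ccc([N+](=O)[O-])cc3)ccc2[nH]1` and compound 2 `Cc1cc2cc(NS(=O)(=O)c3ccccc3)ccc2[nH]1` share one core; compound 3 `O=[N+]([O-])c1ccc(S(=O)(=O)Nc2ccc3ncsc3c2)cc1` and compound 4 `O=S(=O)(Nc1ccc2ncsc2c1)c1ccccc1` share another. The difference between the two cores is not broken down here. In an ADME assay on J774 cells (Mus musculus) for cytotoxicity, read by fluorescence and resazurin assay, with a stated time of 24 h (on this read-out lower numbers stand for higher toxicity in this test and higher numbers for lower toxicity in this test), compound 1 gives 132000 nM. Compound 2 gives only a limit of the assay, >= 300000 nM. The change hydrogen in place of nitro on an aromatic carbon produces an at least 2.2-fold higher number from compound 1 to compound 2 (0.35 log units; beyond the scatter). That step is read against (the limit of >= 300000 nM in this assay, at which 2 of the 3 values shown sit), so its full size is not known.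

Compound 3 also gives only a limit of the assay, >= 300000 nM. Compound 4 carries the same change relative to compound 3, (hydrogen in place of nitro on an aromatic carbon), at the same place of the ring.

The expected step here is a step that the limit leaves unreadable from compound 3 to compound 4, resting on an at least 2.2-fold higher number from compound 1 to compound 2 (0.35 log units; beyond the scatter) pointing toward a higher number and on the limit of compound 3 at the limit of >= 300000 nM in this assay, at which 2 of the 3 values shown sit. Compound 4 is estimated at 400000 nM in this test, between 150000 nM and 1000000 nM, and is expected to be reported as a limit again rather than as a number.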

Compound 4, half-maximal cytotoxic concentration: >= 300000 nM
Compound 4 was reported as a limit (the forecaster's own chance of this, stated with the estimate: 80%); the middle value does not contradict the limit.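

In this assay compound 4 gives >= 300000 nM, a limit of the assay, as compound 3 does, so no step can be read between compound 3 and compound 4: the limit of >= 300000 nM in this assay, at which 3 of the 4 values shown sit.

The compounds shown leave open whether hydrogen in place of nitro on an aromatic carbon changes the read-out on the core of compound 3 as it does on the core of compound 1.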